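Swapping a thiazolylmethoxy arm for phenylsulfanyl on a piperazine amide

A few compounds are considered here, and "the series" means these few. Any claim that something is new, unique, unknown or untested is made for them only; others in the source may bear on it.

Three compounds share a piperazine amide core. Compound 1 `O=C(COCc1ccncc1)N1CCN(c2cc(Cl)ccn2)CC1` gives 4200 nM in a functional assay on HEK293 cells for positive allosteric modulation of metabotropic glutamate receptor 5 (Homo sapiens), read by FLIPR and calcium flux; on this read-out higher numbers stand for an effect only at larger amounts of compound and lower numbers for an effect already at smaller amounts; compound 2 `O=C(COCc1cscn1)N1CCN(c2ccc(Cl)cc2Cl)CC1` gives 290 nM, the second highest of the three numbers, and compound 3 `N#Cc1ccc(COCC(=O)N2CCN(c3ccc(Cl)cc3Cl)CC2)s1` gives 210 nM. Going by the values given here, the only single-point step, a 1.4-fold lower number from compound 2 to compound 3 (0.14 log units; within the scatter), alters the distal ring on the ether-linked carbon and stays within the scatter. Compound 4 `O=C(CSc1ccccc1)N1CCN(c2ccc(Cl)cc2Cl)CC1` differs from compound 2 by phenylsulfanyl in place of (1,3-thiazol-4-yl)methoxy on a saturated chain carbon bound to a carbonyl carbon. Among the compounds with values here, no measured step touches the chain between the carbonyl and the aromatic ring, so the shift is expected to be only modest, a 1.7-fold higher number from compound 2 to compound 4 (0.24 log units; within the scatter), with a somewhat higher number judged slightly more likely. Compound 4 is therefore estimated at 500 nM, within 150 nM to 2000 nM.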

Compound 4, half-maximal effective concentration: > 25000 nM
Compound 4 ended at the assay's limit; the forecaster's own chance of this, stated with the estimate: 5%; middle value at least 50-fold (1.69 log units) from the limit.
By their numbers in this assay, from the lowest: compounds 3 and 2 (each within the scatter of the next); then compound 1. At a limit, above all of these: compound 4.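

Where the change on the distal ring stayed within the scatter, phenylsulfanyl in place of (1,3-thiazol-4-yl)methoxy on a saturated chain carbon bound to a carbonyl carbon gives an at least 86-fold higher number from compound 2 to compound 4 (1.93 log units; beyond the scatter) in this assay. This place therefore separates two groups of equal heavy-atom count very sharply. The figure for compound 4 is a limit and not a number: the limit of > 25000 nM in this assay, at which 1 of the 4 values shown sits.

This single step changes the linking atoms, the chain and the ring together, so the compounds shown cannot say which of them matters. On these data alone, whether benzyloxy or (1,3-thiazol-4-yl)methylsulfanyl at this place would stay near compound 2 remains open.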